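Carbamate replacing the amide-bearing propyl chain at the aryl oxygen

The source may hold more compounds than are shown below. What is called first, only, known or untested is meant among the compounds shown, and "the series" means these compounds.

Compound 1 `CC(C)=CCC/C(C)=C/CC1Cc2c(OCCCNS(=O)(=O)c3ccc(Br)cc3)cc(=O)n(CCCO)c2CC1(C)C` and compound 2 `CC(C)=CCC/C(C)=C/CC1Cc2c(OCCCNC(=O)c3ccco3)cc(=O)n(CCCO)c2CC1(C)C` share one core and differ only in the group on the amine nitrogen. In a functional assay on PANC-1 cells (Homo sapiens) for inhibition, read by MTT assay, with a stated time of 24 h, tested at 10 uM (on this read-out higher numbers stand for more inhibition at the one concentration tested (going by the name of the read-out) and lower numbers for less inhibition), compound 1 gives 15.2%, while compound 2 gives 69.5%, and a number 54.3 percentage points higher from compound 1 to compound 2 (beyond the scatter). Going by the values given here, compound 2 therefore holds the higher of the two numbers, with compound 1 as its only neighbour.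

Compound 3 `CC(C)=CCC/C(C)=C/CC1Cc2c(OC(=O)Nc3ccc(F)c(Cl)c3)cc(=O)n(CCCO)c2CC1(C)C` is built from compound 2 by the change ((3-chloro-4-fluorophenyl)carbamoyl in place of 3-(((furan-2-yl)carbonyl)amino)propyl on an oxygen on an aromatic ring). Among the compounds with values here, no measured step touches this position on the oxygen, and the one step known concerns a different site, so it offers no direct guide. The incoming group carries a halogenated benzene, as does compound 1, which sits low; the departing group carries the furan amide, which sits high. A step downward of moderate size is expected, a number 29.5 percentage points lower from compound 2 to compound 3 (beyond the scatter), with wide uncertainty. For compound 3 the expected value in this assay is 40%, within a range from 10% to 72%.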

Compound 3, a percentage reported as inhibition, at one concentration (the size of the read-out at that concentration, not a potency): 25%
Beside the measured number, compound 3's estimate is 15 percentage points above it; the measured number falls inside the stated range.
By their numbers in this assay, from the lowest: compounds 1 and 3 (each within the scatter of the next); then compound 2.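

The substituent on an oxygen on an aromatic ring proves to be a sensitive position in this assay, not only the group on the amine nitrogen: (3-chloro-4-fluorophenyl)carbamoyl in place of 3-(((furan-2-yl)carbonyl)amino)propyl gives a number 44.5 percentage points lower from compound 2 to compound 3 (beyond the scatter). The two groups have the same heavy-atom and hydrogen-bond donor counts, so neither count separates them, while the furan ring, the propyl chain and the amide all leave in this one change. No supporting data bear on the origin of this step.

Still open, on these data alone, is whether the step follows the carbamoyl link or the 3-chloro-4-fluorophenyl ring. A furan-2-yl ring on the carbamoyl nitrogen, or a longer chain carrying the furan amide, would help separate these parts.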